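Bromine in Place of the Acetylthiophene on the Benzamide

A few compounds are considered here, and "the series" means these few. Any claim that something is new, unique, unknown or untested is made for them only; others in the source may bear on it.

Compound 1, `CCOC(=O)CCCCCOc1cccc(CN(C(=O)c2ccc(-c3ccc(C(C)=O)s3)cc2)C(C)C)c1`: > 26000 nM
Compound 2, `CCOC(=O)CCCCCOc1cccc(CN(C(=O)c2ccc(-c3cc(C(F)(F)F)cc(C(F)(F)F)c3)cc2)C(C)C)c1`: > 26000 nM

In an ADME assay on HepG2 cells (Homo sapiens) for cytotoxicity, read by CellTiter-Glo and resazurin assay, with a stated time of 72 h (a higher number here means that more compound is needed for the effect, a lower number that less compound is needed), compound 1 gives > 26000 nM, which is a limit of the assay and not a number. Compound 2 likewise gives > 26000 nM in this assay, again a limit. Within the data shown here, compound 1 therefore stands nowhere distinct: every value shown here is the limit of > 26000 nM in this assay, at which 2 of the 2 values shown sit, and no measured step between the two compounds can be given, only that neither reached a number.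

Compound 3, `CCOC(=O)CCCCCOc1cccc(CN(C(=O)c2ccc(Br)cc2)C(C)C)c1`, has not yet been measured. It differs from compound 1 by bromo in place of 5-acetylthiophen-2-yl on an aromatic carbon. Among the measured compounds shown here, with both measured compounds resting at the limit, there is no step on record to say how large a change at this position is felt in this assay, so no movement beyond the usual scatter is expected in either direction, and the likeliest outcome is that compound 3 also reports only a limit.

Compound 3 is expected to give about 40000 nM in this assay, with a range from 15000 nM to 120000 nM. The step that the limit leaves unreadable from compound 1 to compound 3 that this estimate implies is expected to be none beyond the scatter.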

Compound 3, half-maximal effective concentration: > 26000 nM
Compound 3 was reported as a limit; the forecaster's own chance of this, stated with the estimate: 80%; the middle value does not contradict the limit.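

No step from compound 1 to compound 3 can be read, and in this assay the three compounds shown give one and the same reading: the limit of > 26000 nM in this assay, at which 3 of the 3 values shown sit.

The compounds shown leave open at what concentration any of them would reach the half-maximal effect, and whether bromo in place of 5-acetylthiophen-2-yl changes that concentration at all.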